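A few compounds are considered here, and "the series" means these few. Any claim that something is new, unique, unknown or untested is made for them only; others in the source may bear on it.

Measured so far:
compound 1 `CNc1nc(NCc2ccc(OC(F)(F)F)cc2)cc(-c2ccccn2)n1` — 7 nM
compound 2 `c1ccc(-c2cc(NCC3CC3)ncn2)nc1` — 10000 nM

In a functional assay on HEK293 cells for agonist activity at G-protein coupled receptor 39 (Mus musculus), read by inositol phosphate accumulation (on this read-out higher numbers stand for an effect only at larger amounts of compound and lower numbers for an effect already at smaller amounts), compound 2 gives 10000 nM, the highest of the two numbers, while compound 1 gives 7 nM; the gap between the two is far beyond the scatter. Compound 1 and compound 2 differ in more than one place, so the two values alone cannot be split between the changes.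

Compound 3 `CNc1nc(NCC2CC2)cc(-c2ccccn2)n1` takes compound 2 and introduces (methylamino in place of hydrogen on an aromatic carbon). It thereby carries the methylamino group of compound 1 but keeps the (cyclopropylmethyl)amino group of compound 2.

Within the data shown here, with no single-change step in hand, the expectation rests on the large gap between compound 2 and compound 1. For compound 3 a step well beyond the scatter toward lower numbers in this assay is expected, a 20-fold lower number from compound 2 to compound 3 (1.30 log units; beyond the scatter), though part of the gap to compound 1 is likely to remain. Compound 3 is estimated at 500 nM, in the range 50 nM to 5000 nM.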

Compound 3, half-maximal effective concentration: 115 nM
The estimate for compound 3 lay 4.3-fold (0.64 log units) above the measured number, within the range that was stated.
By their numbers in this assay, from the lowest: compound 1; then compound 3; then compound 2.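

In this assay the methylamino group on the aromatic carbon between two ring nitrogen atoms brings an 87-fold lower number from compound 2 to compound 3 (1.94 log units; beyond the scatter) with the (cyclopropylmethyl)amino group unchanged, so this one position carries a large step on its own. The earlier pair could not show this, as its changes could not be separated; now compound 3 gives 115 nM and compound 1 gives 7 nM with both carrying the methylamino group and differing only in the other amine substituent. Nothing on hand bears on the origin of the step.

Open, as far as these compounds go, is whether this position needs the methylamino group specifically, or whether an unsubstituted amino group, a dimethylamino group or a methoxy group would give a step of similar size. Also open, from the compounds shown here alone, is whether the step has the same size alongside the amine substituent of compound 1.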